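Swapping a Five-Membered Ring on a Shared Core

The source may report more compounds than this note shows. Statements on the series, on what has been measured and on what is new or still open speak of the compounds shown alone.

Three compounds with one shared core have been measured in a functional assay for activation of Alpha-1B adrenergic receptor (Homo sapiens), read by calcium flux; on this read-out lower numbers stand for an effect already at smaller amounts and higher numbers for an effect only at larger amounts of compound:

compound 1 `Cc1ncc(-c2ccccc2NCC2=NCCN2)o1` gives only a limit of the assay, < 5020 nM
compound 2 `Cc1nc(-c2ccccc2NCC2=NCCN2)cs1` gives 69.2 nM
compound 3 `Cc1cc(-c2ccccc2NCC2=NCCN2)on1` gives 95.5 nM

Compound 3 has the higher of the two real numbers, yet its nearest neighbour is compound 2, and the step of a 1.4-fold higher number from compound 2 to compound 3 (0.14 log units; within the scatter) lies within the scatter, so neither can be called more or less potent than the other. For compound 1 only a limit is known, and the steps a step that the limit leaves unreadable from compound 1 to compound 2 and a step that the limit leaves unreadable from compound 1 to compound 3 therefore cannot be sized, as the limit of < 5020 nM in this assay, at which 1 of the 3 values shown sits, shows.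

Compound 4 `Cc1noc(-c2ccccc2NCC2=NCCN2)n1` differs from compound 3 in one place: 3-methyl-1,2,4-oxadiazol-5-yl in place of 3-methyl-1,2-oxazol-5-yl on an aromatic carbon. Among the measured compounds shown here, the only readable step among the measured compounds, also an exchange of one five-membered aromatic ring for another, stayed within the scatter, while the ring of compound 1 left only a limit. For the measured compounds named here, a third hetero atom in the ring has no measured precedent here, so the expectation is uncertain. Compound 4 is expected to give 220 nM, within 60 nM to 1500 nM. This is expected to mean a 2.3-fold higher number from compound 3 to compound 4 (0.36 log units; beyond the scatter), a step that may or may not exceed the scatter.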

Compound 4, half-maximal effective concentration: < 5020 nM
Compound 4: no number, only a limit (the forecaster's own chance of this, stated with the estimate: 20%); the middle value is on the limit's open side.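

Among the compounds shown here, compound 4, like compound 1, gives only a limit and not a number, so no step from compounds 1, 2 or 3 to compound 4 can be read: the limit of < 5020 nM in this assay, at which 2 of the 4 values shown sit. The compounds shown leave open how far compound 1 and compound 4 lie from compound 2 and compound 3, and whether compound 1 and compound 4 differ from each other.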